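A few compounds are considered here, and "the series" means these few. Any claim that something is new, unique, unknown or untested is made for them only; others in the source may bear on it.

Compound 1 `COC(=O)C1=C(C)NC(=O)N(C(=O)NCCCN2CCN(c3ccc(Cl)cc3)CC2)C1c1ccc(F)c(F)c1` and compound 2 `COC(=O)C1=C(C)NC(=O)N(C(=O)NCCCN2CCN(c3ccc(OC)cc3C)CC2)C1c1ccc(F)c(F)c1` were both tested in an assay on liver for binding affinity to Alpha-1A adrenergic receptor (Homo sapiens), using microsomes; a lower number here means a stronger inhibitor, a higher number a weaker inhibitor. Compound 1 gives 0.8 nM there, while compound 2 gives 16 nM, the highest of the two numbers, with compound 1 as its nearest neighbour a 20-fold higher number from compound 1 to compound 2 (1.30 log units; beyond the scatter). Compound 3 `COC(=O)C1=C(C)NC(=O)N(C(=O)NCCCN2CCN(c3ccccc3Cl)CC2)C1c1ccc(F)c(F)c1` differs from compound 2 by 2-chlorophenyl in place of 4-methoxy-2-methylphenyl on an amine nitrogen in a ring. Going by the values given here, only the step from compound 1 to compound 2 bears on this change, and it was large. A chlorophenyl group returns in compound 3, though on a different position than in compound 1, so a lower number is expected, of the size a 5.3-fold lower number from compound 2 to compound 3 (0.73 log units; beyond the scatter). Compound 3 is therefore estimated at 3 nM, within 0.8 nM to 12 nM.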

Compound 3, inhibition constant: 0.2 nM
Compound 3: middle estimate off by 15-fold (1.18 log units), on the high side; the whole stated range lies above it.
By their numbers in this assay, from the lowest: compound 3; then compound 1; then compound 2.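

In this assay, the place of the chlorine on the phenyl ring matters: 2-chlorophenyl in place of 4-chlorophenyl gives a 4.0-fold lower number from compound 1 to compound 3 (0.60 log units; beyond the scatter). Replacing 4-methoxy-2-methylphenyl with 2-chlorophenyl gives a much larger change, an 80-fold lower number from compound 2 to compound 3 (1.90 log units; beyond the scatter), so this position on the ring amine nitrogen responds strongly to the group it carries. Still open, going by these compounds, is how a 2-methoxyphenyl or 2-fluorophenyl group would compare with 2-chlorophenyl. Nothing available here explains why either change shifts the number.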